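A few compounds are considered here, and "the series" means these few. Any claim that something is new, unique, unknown or untested is made for them only; others in the source may bear on it.

Working notes on the series. Compound 1 `CC(Oc1cccnc1Nc1cnn(C)c1)c1cccc(C(=O)NCc2ccc(OC(F)(F)F)cc2)c1`, compound 2 `CC(Oc1cccnc1Nc1cnn(C)c1)c1cccc(C(=O)NCc2ccc(Cl)c(C(F)(F)F)c2)c1` and compound 3 `Cc1ccc(CNC(=O)c2cccc(C(C)Oc3cccnc3Nc3ncccn3)c2)cc1` have been measured in a functional assay on HCC78 cells (Homo sapiens) for antiproliferative activity, read by MTT assay, with a stated time of 48 h (on this read-out higher numbers stand for weaker inhibition and lower numbers for stronger inhibition), while compound 4 `Cc1ccc(CNC(=O)c2cccc(C(C)Oc3cccnc3Nc3ncc(C)s3)c2)cc1` has not. In this assay, among the measured compounds shown here, compound 1 gives 73900 nM and compound 2 gives 48600 nM; the only single-change step measured, a 1.5-fold lower number from compound 1 to compound 2 (0.18 log units; within the scatter), lies elsewhere on the molecule. For compound 3 this assay reports only a limit, > 100000 nM, which is the limit of > 100000 nM in this assay, at which 1 of the 3 values shown sits. The change from compound 3 to compound 4 is 5-methyl-1,3-thiazol-2-yl in place of pyrimidin-2-yl on a nitrogen on an aromatic ring. No measured step touches this position, so nothing shown fixes the size or direction of the step. Compound 4 is estimated at 90000 nM, with a range from 30000 nM to 250000 nM. The step thereby expected is an at least 1.1-fold lower number from compound 3 to compound 4 (0.04 log units; that floor lies within the scatter).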

Compound 4, half-maximal inhibitory concentration: 14800 nM
For compound 4 the middle estimate is 6.1-fold (0.78 log units) above the measured one; measured number below the stated range.
By their numbers in this assay, from the lowest: compound 4; then compounds 2 and 1 (each within the scatter of the next). At a limit, above all of these: compound 3.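

In this assay the change from pyrimidin-2-yl to 5-methyl-1,3-thiazol-2-yl gives an at least 6.7-fold lower number from compound 3 to compound 4 (0.82 log units; beyond the scatter), the first step read at this position. Compound 3 gives > 100000 nM, which is a limit and not a number, so only a floor is known for this step. The group on this nitrogen therefore matters in this series, although both groups have the same heavy-atom count.

From the compounds shown here alone, whether the five-membered ring or its methyl carries the step stays open. So does how an amine or a longer chain in place of that methyl would read.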